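This account rests on a few compounds, and the source may have more. Where it says the series, first, only, none or still open, it means among the compounds named here.

Measured so far in a physicochemical assay for solubility, read by HPLC, in phosphate buffer, with a stated time of 24 h, at pH 7.4, tested at 120 uM; a higher number here means a more soluble compound, a lower number a less soluble compound:
compound 1 `COC(=O)CC[C@H](NC(=O)c1c(C)[nH]c(/C=C2\C(=O)Nc3ccc(C(=O)O)cc32)c1C)C(=O)OC`: >= 120000 nM
compound 2 `COC(=O)CC[C@H](NC(=O)c1ccc2c(c1)/C(=C/c1[nH]c(C)c(C(=O)O)c1C)C(=O)N2)C(=O)OC`: 100000 nM

The value of compound 1 is a limit of this assay, not a number: the limit of >= 120000 nM in this assay, at which 1 of the 2 values shown sits. Compound 2, in this assay, gives 100000 nM as a number. Compound 3 `COC(=O)CC[C@H](NC(=O)c1c(C)[nH]c(/C=C2\C(=O)Nc3ccc(C(=O)OC)cc32)c1C)C(=O)OC` is not yet measured in this assay; it differs from compound 1 by methyl in place of hydrogen on an oxygen next to a carbonyl group. The expected step is an at least 4.0-fold lower number from compound 1 to compound 3 (0.60 log units; beyond the scatter), downward and beyond the usual scatter. Compound 3 is estimated at 30000 nM in this assay, within a range from 8000 nM to 120000 nM.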

Compound 3, solubility: < 5000 nM
Compound 3: no number, only a limit; the forecaster's own chance of this, stated with the estimate: 15%; at least 6.0-fold (0.77 log units) between middle value and limit.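

Carboxy to methoxycarbonyl on the core of compound 1 gives, in this assay, an at least 24-fold lower number from compound 1 to compound 3 (1.38 log units; beyond the scatter), the first step in the series between compounds that differ in one place. Compound 1 stands at a limit, not a number: the limit of >= 120000 nM in this assay, at which 1 of the 3 values shown sits. Compound 3 also stands at a limit, not a number: the limit of < 5000 nM in this assay, at which 1 of the 3 values shown sits.

On these data alone, the step therefore gives only a minimum size, and its full size stays open. As far as these compounds go, how a primary amide or an amine in place of the carboxy would read in this assay also stays open, as does the same methyl change on the carboxy of compound 2.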